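Amide aryl swap on the shared core

The source may hold more compounds than are shown below. What is called first, only, known or untested is meant among the compounds shown, and "the series" means these compounds.

Working notes on a small amide series. Compound 1 `Cc1ccc(C(=O)Nc2cccc(-c3ccnc4c(N)cccc34)c2)cc1C` and compound 2 `Nc1cccc2c(-c3cccc(NC(=O)c4cc(Cl)cc(C(F)(F)F)c4)c3)ccnc12` keep the core of compound 1 and differ only in the aryl group on the carbonyl carbon. In a functional assay on A375P cells (Homo sapiens) for antiproliferative activity, read by MTT assay, with a stated time of 48 h (a lower number here means a stronger inhibitor, a higher number a weaker inhibitor), compound 1 gives > 20000 nM, which is a limit of the assay and not a number (the limit of > 20000 nM in this assay, at which 1 of the 2 values shown sits). In this assay compound 2 gives 18500 nM. Taken together the two values show only that both compounds are weak; with compound 1 sitting at its limit, no order between them can be read.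

Compound 3 `Cc1cc(C(=O)Nc2cccc(-c3ccnc4c(N)cccc34)c2)c(C)o1` is not yet measured. It differs from compound 1 by 2,5-dimethylfuran-3-yl in place of 3,4-dimethylphenyl on a carbonyl carbon. For the measured compounds named here, no step between measured compounds covers such a swap, so no measured direction is known for it. Because compound 1 gives only > 20000 nM, the step is expected to be a step that the limit leaves unreadable from compound 1 to compound 3, nothing beyond the usual scatter. The value estimated for compound 3 in this assay is 22000 nM, in a range from 8000 nM to 60000 nM, with a fair chance that again only a limit is reported.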

Compound 3, half-maximal inhibitory concentration: > 20000 nM
Compound 3 was reported as a limit (the forecaster's own chance of this, stated with the estimate: 55%); the middle value does not contradict the limit.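

In this assay compound 3 gives > 20000 nM, a limit of the assay and not a number. No step between compound 1 and compound 3 can be read, because both stand at the same limit: the limit of > 20000 nM in this assay, at which 2 of the 3 values shown sit.

The compounds shown leave open whether 2,5-dimethylfuran-3-yl or 3,4-dimethylphenyl on the carbonyl carbon gives the stronger inhibitor in this assay.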